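The compounds below may be only part of what the source reports. "The series", "measured", "known", "first", "only" and "open" are said of these compounds alone.

Of the compounds shown here, three built on one shared core have been measured in an assay on isolated protein for inhibition of coagulation factor X (Oryctolagus cuniculus), tested at 1 uM; a lower number here means less inhibition, a higher number more inhibition at the concentration tested (going by the name of the read-out). Compound 1, `O=C1[C@@H](NS(=O)(=O)c2ccc(-c3ccon3)s2)CCN1Cc1cc2cc[nH]cc-2n1`, gives 49% in this assay. Compound 3, `O=C1[C@@H](NS(=O)(=O)c2ccc(-c3ccncc3)s2)CCN1Cc1cc2c[nH]ccc-2n1`, gives 21%. Compound 2, `O=C1[C@@H](NS(=O)(=O)c2cc3ncccc3s2)CCN1Cc1cc2c[nH]ccc-2n1`, gives 61%, the highest of the three numbers: its nearest neighbour is compound 1, which stands lower by more than the usual scatter, and compound 3 stands lower still, again beyond the scatter. No two of these compounds differ in only one place, so the numbers alone do not show which part of each structure drives the differences.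

Compound 4, `O=C1[C@@H](NS(=O)(=O)c2cc3cccnc3s2)CCN1Cc1cc2c[nH]ccc-2n1`, has not yet been measured. It differs from compound 2 by a group of 9 heavy atoms (7 carbon, 1 nitrogen, 1 sulfur; one five-membered aromatic ring with 1 hetero atom, one six-membered aromatic ring with 1 hetero atom) in place of a group of 9 heavy atoms (7 carbon, 1 nitrogen, 1 sulfur; one five-membered aromatic ring with 1 hetero atom, one six-membered aromatic ring with 1 hetero atom), on a sulfonyl sulfur. The group that leaves and the group that enters contain the same atoms and the same kinds of rings, joined differently. For the measured compounds named here, no step of this kind between two measured compounds is on hand, so the size of the change has to be guessed. A rearrangement that adds and removes nothing is expected to move the number only moderately, more likely downward, since compound 2 already sits at the top of the measured range with 61%. The step from compound 2 to compound 4 is estimated at a number 11 percentage points lower from compound 2 to compound 4 (beyond the scatter). Compound 4 is expected to give 50% in this assay, with a likely range from 28% to 70%.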

Compound 4, a percentage reported as inhibition, at one concentration (the size of the read-out at that concentration, not a potency): 18%
Compound 4: middle estimate off by 32 percentage points, on the high side; measured number below the stated range.
By their numbers in this assay, from the lowest: compounds 4 and 3 (each within the scatter of the next); then compound 1; then compound 2.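

For the compounds shown here, the change on the sulfonyl sulfur gives a number 43 percentage points lower from compound 2 to compound 4 (beyond the scatter) in this assay, the first reading in this set of what this one place contributes with the rest of the molecule held fixed. The group that leaves and the group that enters match in their atoms, their kinds of rings, and their counts of hydrogen-bond donors and acceptors, so those counts cannot separate the two, yet the way the same atoms are joined still produces a large step. The measurements on hand do not explain why this rearrangement has so large an effect.

Still open, as far as these compounds go, is whether a group with no ring nitrogen, such as benzothiophene, or a simple phenyl ring on the sulfonyl sulfur would give a number closer to that of compound 2 or to that of compound 4. Also open, from the compounds shown here alone, is whether the same rearrangement would produce a step of similar size on the core of compound 1, since this single step comes from one core only.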